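The source may hold more compounds than are shown below. What is called first, only, known or untested is meant among the compounds shown, and "the series" means these compounds.

Measured compounds:
Compound 1, `CN(C)CCn1c(N)c(-c2nc3ccccc3[nH]2)c2nc(C#N)c(C#N)nc21`: 9730 nM
Compound 2, `CCN(CC)CCn1c(N)c(-c2nc3ccccc3[nH]2)c2nc(C#N)c(C#N)nc21`: 12200 nM
Compound 3, `CN(C)CCCCn1c(N)c(-c2nc3ccccc3n2C)c2nc(C#N)c(C#N)nc21`: 3870 nM

In an ADME assay on HEK293 cells (Homo sapiens) for cytotoxicity, read by MTT assay, with a stated time of 48 h (on this read-out lower numbers stand for stronger inhibition and higher numbers for weaker inhibition), compound 1 gives 9730 nM and compound 2 gives 12200 nM. The change between them, (diethylamino in place of dimethylamino on a saturated chain carbon, two bonds along the chain from an aromatic nitrogen), made a step of a 1.3-fold higher number from compound 1 to compound 2 (0.10 log units; within the scatter). Compound 3 gives 3870 nM; the difference between its core and that of compound 1 is not broken down here. Compound 4, `CCN(CC)CCCCn1c(N)c(-c2nc3ccccc3n2C)c2nc(C#N)c(C#N)nc21`, has not yet been measured in this assay. It differs from compound 3 by diethylamino in place of dimethylamino on a saturated chain carbon, four bonds along the chain from an aromatic nitrogen. This is the same kind of change as from compound 1 to compound 2, but the place differs: two bonds along the chain from an aromatic nitrogen there, four bonds along the chain from an aromatic nitrogen here. Because the earlier step was a 1.3-fold higher number from compound 1 to compound 2 (0.10 log units; within the scatter), the step from compound 3 to compound 4 is expected to be similarly small, about a 1.2-fold higher number from compound 3 to compound 4 (0.09 log units; within the scatter). Compound 4 is therefore estimated at 4800 nM, between 2500 nM and 9500 nM.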

Compound 4, half-maximal inhibitory concentration: 3160 nM
Compound 4: middle estimate off by 1.5-fold (0.18 log units), on the high side; the measured number falls inside the stated range.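

In this assay, putting diethylamino in place of dimethylamino gives a 1.2-fold lower number from compound 3 to compound 4 (0.09 log units; within the scatter), and this small step agrees with the one seen on the other core: the same change on two cores in this assay, a 1.3-fold higher number (0.10 log units; within the scatter) from compound 1 to compound 2 and a 1.2-fold lower number (0.09 log units; within the scatter) from compound 3 to compound 4, 1.5-fold (0.19 log units) apart, within the scatter of two such steps On these two cores, then, the change carries over as a step too small to tell from scatter, whether it sits two or four bonds along the chain from an aromatic nitrogen. This does not show that the change would stay as small on other cores, and two pairs cannot give the step a reliable direction.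

Going by these compounds, it remains open whether a cyclic amine such as piperidine or morpholine in place of diethylamino would behave in the same way. On these data alone, it is also open whether the same would hold on a longer chain.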